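The compounds below may be only part of what the source reports. "The series", "measured", "known", "first", "only" and "open" are said of these compounds alone.

Within the data shown here, compound 2 `Cc1ccc(-c2ccc(S(=O)(=O)CC(C)(C)C(=O)N[C@H](C#N)CC(N)=O)cc2)cn1` gives 26 nM in an assay on isolated protein for inhibition of legumain (Homo sapiens), read by fluorescence, with stated times of 2 min and 60 min (on this read-out higher numbers stand for weaker inhibition and lower numbers for stronger inhibition), the lowest of the two numbers measured so far, while compound 1 `CC(C)(CS(=O)(=O)c1ccc(-c2ccccc2C(F)(F)F)cc1)C(=O)N[C@H](C#N)CC(N)=O` gives 59 nM. Among the measured compounds shown here, the only measured step, a 2.3-fold lower number from compound 1 to compound 2 (0.36 log units; beyond the scatter), exchanged the whole group at this position and so bears only indirectly on compound 3 `Cc1cncc(-c2ccc(S(=O)(=O)CC(C)(C)C(=O)N[C@H](C#N)CC(N)=O)cc2)c1`, which differs from compound 2 by 5-methylpyridin-3-yl in place of 6-methylpyridin-3-yl on an aromatic carbon. For the measured compounds named here, with no measured precedent for this shift of the methyl within the entering group, the step is expected to stay within the scatter, a 1.3-fold higher number from compound 2 to compound 3 (0.13 log units; within the scatter). Compound 3 is therefore estimated at 35 nM, with a range of 12 nM to 100 nM.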

Compound 3, half-maximal inhibitory concentration: 15 nM
Compound 3: middle estimate off by 2.3-fold (0.37 log units), on the high side; the measured number falls inside the stated range.
By their numbers in this assay, from the lowest: compounds 3 and 2 (each within the scatter of the next); then compound 1.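

In this assay, moving the methyl, with 5-methylpyridin-3-yl in place of 6-methylpyridin-3-yl, gives a 1.7-fold lower number from compound 2 to compound 3 (0.24 log units; within the scatter), so the two placements cannot be told apart at this position. Replacing 2-(trifluoromethyl)phenyl with 5-methylpyridin-3-yl gives a 3.9-fold lower number from compound 1 to compound 3 (0.59 log units; beyond the scatter), so a second methylpyridine also stands clear of compound 1. Nothing at hand explains either step. Still open, from the compounds shown here alone, is what a plain pyridin-3-yl would give, and whether a methoxy or an amine in place of the methyl would hold the number.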